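Shortening the Chain of Compound 2 by Butyl

This account rests on a few compounds, and the source may have more. Where it says the series, first, only, none or still open, it means among the compounds named here.

Measured in a functional assay on B16-F10 cells (Mus musculus) for antiproliferative activity, read by MTT assay, with a stated time of 72 h; on this read-out higher numbers stand for weaker inhibition and lower numbers for stronger inhibition:
compound 1 `CCCCCCCCCCCCNC[C@@H]1OC[C@H](N)[C@H]1O`: 58100 nM
compound 2 `CCCCCCCCCCCCCCNC[C@@H]1OC[C@H](N)[C@H]1O`: 64300 nM
compound 3 `CCCCCCCCCCCCNC[C@@H]1OC[C@H](N)[C@@H]1O`: 10700 nM

Compound 2 lies within the scatter of compound 1, and compound 3 gives a clearly lower number than both. Compound 4 `CCCCCCCCCCNC[C@@H]1OC[C@H](N)[C@H]1O` carries hydrogen in place of butyl on a saturated chain carbon, ten or more bonds along the chain from an amine nitrogen. Among the compounds with values here, the one measured chain step, a 1.1-fold higher number from compound 1 to compound 2 (0.04 log units; within the scatter), stayed within the scatter, although it involved only ethyl. The larger step, a 5.4-fold lower number from compound 1 to compound 3 (0.73 log units; beyond the scatter), reflects the fact that compounds 1 and 3 differ only in the configuration as drawn and does not apply, as compound 4 keeps the configuration of compound 2. No change beyond the scatter is therefore expected in this assay, and the expected step is a 1.1-fold higher number from compound 2 to compound 4 (0.04 log units; within the scatter) here. For compound 4 the estimate is 70000 nM, with an expected range from 30000 nM to 150000 nM here.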

Compound 4, half-maximal inhibitory concentration: > 128000 nM
Compound 4: no number, only a limit; the forecaster's own chance of this, stated with the estimate: 15%; middle value at least 1.8-fold (0.26 log units) from the limit.
By their numbers in this assay, from the lowest: compound 3; then compounds 1 and 2 (each within the scatter of the next). At a limit, above all of these: compound 4.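

In this assay compound 4 gives no number, and what stands in its place is a limit: the limit of > 128000 nM in this assay, at which 1 of the 4 values shown sits.

The step for hydrogen in place of butyl, an at least 1.9-fold higher number from compound 2 to compound 4 (0.29 log units; that floor lies within the scatter), does not pass the scatter at its floor, but the step for hydrogen in place of ethyl, an at least 2.2-fold higher number from compound 1 to compound 4 (0.34 log units; beyond the scatter), does. So this place on the chain, which showed no change beyond the scatter among the longer chains, does respond once the chain is shorter.

Going by these compounds, how far compound 4 lies past its limit stays open. So does how a chain ending in a carboxylic acid or an amine would read at this place.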